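Substituent change on the phenyl ring of the sulfone

The source may report more compounds than this note shows. Statements on the series, on what has been measured and on what is new or still open speak of the compounds shown alone.

Compound 1 `O=S(=O)(c1ccccc1)c1ccc(O)nn1` is the unsubstituted member of the series. Going by the values given here, in a functional assay on the whole organism for inhibition, with Rattus norvegicus as the target, with a stated time of 60 min, at pH 4.5, at a dose of 10 mg/kg by the oral route (a higher number here means a stronger effect of the compound at the dose given, a lower number a weaker effect), compound 1 gives 14%, the lowest of the three numbers measured so far. Compound 2 `O=S(=O)(c1ccc(O)nn1)c1ccccc1F` gives 34% and compound 3 `O=S(=O)(c1ccc(O)nn1)c1ccc(F)cc1Cl` gives 87%. Among the compounds with values here, the one single-place step recorded, fluoro in place of hydrogen on an aromatic carbon, is a number 20 percentage points higher from compound 1 to compound 2 (beyond the scatter). Compound 3 differs from compound 1 in two places at once, so the wide gap between their two values is noted but not treated as a single step.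

Compound 4 `O=S(=O)(c1ccc(C(F)(F)F)cc1)c1ccc(O)nn1` remains to be measured. It differs from compound 1 by trifluoromethyl in place of hydrogen on an aromatic carbon. Within the data shown here, the only measured step that bears on this change is the fluoro step, modest and beyond the scatter, which also places a new group on the same carbon-only ring. The same direction is therefore expected, with a step of similar or somewhat larger size. For compound 4 the expected step is a number 26 percentage points higher from compound 1 to compound 4 (beyond the scatter). For compound 4 the estimate in this assay is 40%, with a range from 15% to 70%.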

Compound 4, a percentage reported as inhibition, in the whole organism at one dose (the size of the read-out at that dose, not a potency): 10%
Compound 4: the middle estimate sits 30 percentage points above what was measured, and the stated range ends above it.
By their numbers in this assay, from the lowest: compounds 4 and 1 (each within the scatter of the next); then compound 2; then compound 3.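

In this assay, trifluoromethyl in place of hydrogen on an aromatic carbon, para to a large group, gives a number 4 percentage points lower from compound 1 to compound 4 (within the scatter), so compound 4 cannot be told apart from the unsubstituted compound 1. Going by these compounds alone, a new group on this ring is therefore not enough by itself to raise the number: the fluoro step, a number 20 percentage points higher from compound 1 to compound 2 (beyond the scatter), has no counterpart with trifluoromethyl at this place. No measurement available here bears on the reason for this result.

Open, from the compounds shown here alone, is whether a single chloro, a methoxy group, an amine or a carboxylic acid on the same carbon would give a number beyond the scatter from compound 1. Also open, going by these compounds, is how the two ring substituents of compound 3 each contribute to its value, since its two changes cannot be read separately.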